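The source may report more compounds than this note shows. Statements on the series, on what has been measured and on what is new or still open speak of the compounds shown alone.

Three compounds of a shared core have been examined in a physicochemical assay for solubility, measured as kinetic solubility, at pH 2; a lower number here means a less soluble compound, a higher number a more soluble compound. Compound 1 `C/C(=C1/OC(=O)NC1=O)C(c1ccc(-c2ccc3cccc(F)c3c2)[nH]c1=O)C(C)C` gives 12700 nM. Compound 2 `CC(C)C(c1ccc(-c2ccc3cccc(F)c3c2)[nH]c1=O)C1SC(=O)NC1=O` gives 11300 nM. Compound 3 `CC(C)[C@H](C[C@@H]1OC(=O)NC1=O)c1ccc(-c2ccc3cccc(F)c3c2)[nH]c1=O` gives 25100 nM. Compound 2 thus has the lowest of the three numbers; compound 1 sits closest to it, within the scatter, while compound 3 lies furthest, beyond the scatter.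

The next compound is compound 4 `CC(C)C(CC1NC(=O)NC1=O)c1ccc(-c2ccc3cccc(F)c3c2)[nH]c1=O`. Relative to compound 2 it carries (2,5-dioxoimidazolidin-4-yl)methyl in place of 2,4-dioxo-1,3-thiazolidin-5-yl on a saturated chain carbon bound to an aromatic carbon and a saturated chain carbon.

Going by the values given here, only one measured step is directly comparable: the exchange of one five-membered ring for another on the same chain carbon, a 1.1-fold lower number from compound 1 to compound 2 (0.05 log units; within the scatter), which changed nothing beyond the scatter. That argues that swapping the ring alone need not move this assay. The change to compound 4, however, also inserts a methyl link between the chain carbon and the ring, and compound 3, which has such a link, shows a higher number than compound 2. On that basis a modest rise is expected, a 1.8-fold higher number from compound 2 to compound 4 (0.25 log units; within the scatter), though the data are too few to make this firm. Compound 4 is therefore estimated at 20000 nM, with a range from 10000 nM to 40000 nM.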

Compound 4, solubility: 13000 nM
Compound 4: middle estimate off by 1.5-fold (0.19 log units), on the high side; low and high end bracket the measured number.
By their numbers in this assay, from the lowest: compounds 2, 1, 4 and 3 (each within the scatter of the next, the first and the last beyond it).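

In this assay, moving to (2,5-dioxoimidazolidin-4-yl)methyl in place of 2,4-dioxo-1,3-thiazolidin-5-yl gives a 1.2-fold higher number from compound 2 to compound 4 (0.06 log units; within the scatter), so this exchange, which changes the ring and also adds a methyl link, stays inside the scatter on this saturated chain carbon bound to an aromatic carbon and a saturated chain carbon. The group of compound 1 gives the same picture, with a 1.0-fold higher number from compound 1 to compound 4 (0.01 log units; within the scatter), which means that all three steps among compounds 1, 2 and 4 now lie within the scatter, and these three different ring-bearing groups cannot be told apart in this read-out. Nothing shown here accounts for why these groups read alike.

All of the groups compared at this position carry a five-membered non-aromatic ring with 2 hetero atoms, so the result says nothing about groups of another kind, such as an amine or a carboxylic acid on the same chain carbon. From the compounds shown here alone, a longer chain between that carbon and the ring is also untested by these compounds, so how far the read-out tolerates changes here remains open.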